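This account rests on a few compounds, and the source may have more. Where it says the series, first, only, none or still open, it means among the compounds named here.

In a physicochemical assay for solubility (a lower number here means a less soluble compound, a higher number a more soluble compound), three compounds have measured values:

- compound 1 `CC(C)(C)OC(=O)N1CCC[C@@H]1C(=O)N1CCC(NS(=O)(=O)c2cc(S(=O)(=O)c3ccccc3)ccc2C(F)(F)F)CC1` gives 25000 nM
- compound 2 `O=C1CC[C@@H](C(=O)N2CCC(NS(=O)(=O)c3cc(S(=O)(=O)c4ccccc4)ccc3C(F)(F)F)CC2)N1` gives 100000 nM
- compound 3 `CC(C)(C)C(=O)N1CCC[C@H]1C(=O)N1CCC(NS(=O)(=O)c2cc(S(=O)(=O)c3ccccc3)ccc2C(F)(F)F)CC1` gives 50000 nM

The value of compound 3 lies within the scatter of both other compounds, as two steps show (a 2.0-fold higher number from compound 1 to compound 3 (0.30 log units; within the scatter)) and (a 2.0-fold lower number from compound 2 to compound 3 (0.30 log units; within the scatter)). Among the measured compounds shown here, only the step between the other two goes beyond the scatter, and it is modest (a 4.0-fold higher number from compound 1 to compound 2 (0.60 log units; beyond the scatter)).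

Compound 4 `O=C([C@@H]1CCCN1C(=O)Nc1ccccc1)N1CCC(NS(=O)(=O)c2cc(S(=O)(=O)c3ccccc3)ccc2C(F)(F)F)CC1` differs from compound 3 in one place (anilino in place of tert-butyl on a carbonyl carbon): anilino in place of tert-butyl on a carbonyl carbon. For the measured compounds named here, no measured step makes this exchange, and none brings in an aromatic ring. The three measured steps bear on it only loosely, since they alter the same part of the compounds, and none of them is more than modest. Going by the values given here, the one step beyond the scatter takes away the tert-butoxycarbonyl group and ends on a higher number, while the present exchange puts in the larger group. On that single thin precedent, a modest step to a lower number is tentatively expected in this assay rather than a large one. The expected change is a 2.5-fold lower number from compound 3 to compound 4 (0.40 log units; beyond the scatter) and remains uncertain in direction. For compound 4 the estimated value is 20000 nM with an expected range from 6000 nM to 50000 nM in this estimate.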

Compound 4, solubility: 25000 nM
The estimate for compound 4 lay 1.3-fold (0.10 log units) below the measured number, within the range that was stated.
By their numbers in this assay, from the lowest: compounds 1, 4, 3 and 2 (each within the scatter of the next, the first and the last beyond it).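

In this assay, the exchange of tert-butyl for anilino on a carbonyl carbon brings an aromatic ring to this position for the first time among these compounds, and it gives a step that stays inside the usual scatter (a 2.0-fold lower number from compound 3 to compound 4 (0.30 log units; within the scatter)). Among the compounds shown here, compound 3 and compound 4 therefore cannot be told apart in this read-out, even though the entering group adds one six-membered aromatic ring of carbon and one hydrogen-bond donor, and the earlier steps at this place had not tested either feature. Nothing measured here gives a reason for this result.

Going by these compounds, what remains open is whether anything placed on this carbonyl carbon can move the number beyond the scatter in the way seen for the exchange of the whole acyl-bearing ring (a 4.0-fold higher number from compound 1 to compound 2 (0.60 log units; beyond the scatter)), since the anilino exchange alone does not. The compounds shown also leave open whether a cyclohexylamino group, or an anilino group bearing a carboxylic acid or a dimethylamino substituent, would stay as close to compound 3, and they do not separate the contribution of the aromatic ring from that of the added nitrogen.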